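Hydroxy variant of compound 2 in the growth assay

The source may report more compounds than this note shows. Statements on the series, on what has been measured and on what is new or still open speak of the compounds shown alone.

Among the compounds with values here, compound 2 `COc1nc2sc(C)cn2c1/C=C1/C(=O)Nc2ccccc21` stands at the high end of the two numbers so far. In a functional assay on cells (Breast carcinoma cell, Homo sapiens) for cytotoxicity, read by sulforhodamine B assay, with a stated time of 48 h (a lower number here means a stronger inhibitor of growth, a higher number a weaker inhibitor of growth), compound 2 gives 2520 nM, while compound 1 `COc1ccc2c(c1)/C(=C/c1c(-c3ccncc3)nc3sccn13)C(=O)N2C` gives 440 nM, a gap beyond the usual scatter. Compound 3 `COc1nc2sc(C)cn2c1/C=C1/C(=O)Nc2ccc(O)cc21` differs from compound 2 by a single change: hydroxy in place of hydrogen on an aromatic carbon. Within the data shown here, no measured pair shows this change, so nothing in the data fixes its size; compound 3 is expected to shift only by a 1.1-fold lower number from compound 2 to compound 3 (0.06 log units; within the scatter), which is no move beyond the scatter. Compound 3 is estimated at 2200 nM, with a range of 900 nM to 5500 nM.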

Compound 3, concentration for 50% growth inhibition: 4570 nM
For compound 3 the middle estimate is 2.1-fold (0.32 log units) below the measured one; the range from low to high includes it.
By their numbers in this assay, from the lowest: compound 1; then compounds 2 and 3 (each within the scatter of the next).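

In this assay, within the data shown here, hydroxy in place of hydrogen on an aromatic carbon gives a 1.8-fold higher number from compound 2 to compound 3 (0.26 log units; within the scatter), the first reading of any change at this position. This aromatic carbon therefore carries a hydroxy group with no move beyond the scatter, and the change brings no measurable gain in growth inhibition. Nothing at hand bears on the origin of this small step. From the compounds shown here alone, whether an amine or a carboxylic acid on the same carbon would leave the number within the scatter remains open. So does whether hydroxy would behave alike on the core of compound 1.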